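Substituent swaps on the aryl ring of compound 1

The source may report more compounds than this note shows. Statements on the series, on what has been measured and on what is new or still open speak of the compounds shown alone.

Compound 1 `CN(C)C/C=C(/c1ccccc1)c1cccnc1`: 27000 nM
Compound 2 `CN(C)C/C=C(/c1ccc(C(F)(F)F)cc1)c1cccnc1`: 13000 nM
Compound 3 `Cc1ccc(/C(=C/CN(C)C)c2cccnc2)cc1`: > 29000 nM

In a functional assay on brain for inhibition of Norepinephrine transporter (Rattus norvegicus) (on this read-out higher numbers stand for weaker inhibition and lower numbers for stronger inhibition), compound 1 gives 27000 nM. Among the two plain numbers, compound 1 stands highest; the nearest is compound 2, reached by a 2.1-fold lower number from compound 1 to compound 2 (0.32 log units; beyond the scatter). For compound 3 only a limit of the assay is reported, > 29000 nM, so its number is not known (the limit of > 29000 nM in this assay, at which 1 of the 3 values shown sits). From compound 1 to compound 3 the change is an at least 1.0-fold higher number from compound 1 to compound 3 (0.03 log units; that floor lies within the scatter), and from compound 2 to compound 3 it is an at least 2.2-fold higher number from compound 2 to compound 3 (0.34 log units; beyond the scatter).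

Compound 4 `CN(C)C/C=C(\c1cccnc1)c1cccc(Cl)c1` differs from compound 1 by chloro in place of hydrogen on an aromatic carbon; the chloro sits on an aromatic carbon of a six-membered aromatic ring of carbon only, meta to a large group. The two measured steps that bear on it both put a single group on the same ring of compound 1: the trifluoromethyl lowered the number modestly, the methyl left it at a limit. Neither step involves chloro, and neither places its group meta to a large group. Compound 4 is therefore expected to sit close to compound 1, with at most a modest lowering of the number, a step of a 1.7-fold lower number from compound 1 to compound 4 (0.23 log units; within the scatter). The estimate for compound 4 in this assay is 16000 nM, between 6000 nM and 40000 nM.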

Compound 4, half-maximal inhibitory concentration: 11000 nM
Compound 4: the middle estimate sits 1.5-fold (0.16 log units) above what was measured, within the range that was stated.
By their numbers in this assay, from the lowest: compounds 4 and 2 (each within the scatter of the next); then compound 1. At a limit, above all of these: compound 3.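

Chloro on an aromatic carbon, meta to a large group, gives in this assay a 2.5-fold lower number from compound 1 to compound 4 (0.39 log units; beyond the scatter) and so shows, for the first time in this set, that a substituent placed there can lower the number on the shared core. The only earlier lowering was the trifluoromethyl step, a 2.1-fold lower number from compound 1 to compound 2 (0.32 log units; beyond the scatter) and together the two steps show that a lowering is not tied to that one group or to one place on this ring, though the numbers of both compounds remain in the same high range. The pattern does not cover compound 3, which stands at > 29000 nM as a limit of the assay and not a number, so its methyl step cannot be read as a lowering or a rise.

As far as these compounds go, whether fluoro, bromo, methoxy or a nitrile at this same place would lower the number as well remains open, as does what chloro would do elsewhere on the ring. Nothing given here accounts for the size of the chloro step.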